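Replacing a Cyanobenzyl Group with Methylsulfonyl

The source may hold more compounds than are shown below. What is called first, only, known or untested is meant among the compounds shown, and "the series" means these compounds.

Measured in an ADME assay on MT4 cells (Homo sapiens) for cytotoxicity, read by MTT assay, with a stated time of 5 days; a higher number here means that more compound is tolerated, a lower number that less compound is tolerated:
Compound 1 `Cc1cc(C)cc(S(=O)(=O)c2c(C(N)=O)[nH]c3ccc(Cl)cc23)c1`: 13000 nM
Compound 2 `Cc1cc(C)cc(S(=O)(=O)c2c(C(=O)N[C@@H]3CCNC3)[nH]c3ccc(Cl)cc23)c1`: 37300 nM
Compound 3 `Cc1cc(C)cc(S(=O)(=O)c2c(C(=O)N[C@@H]3CCN(Cc4ccccc4C#N)C3)[nH]c3ccc(Cl)cc23)c1`: >= 186000 nM, which is a limit and not a number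

Compound 3 stands at the limit of >= 186000 nM in this assay, at which 1 of the 3 values shown sits. Compound 4 `Cc1cc(C)cc(S(=O)(=O)c2c(C(=O)N[C@@H]3CCN(S(C)(=O)=O)C3)[nH]c3ccc(Cl)cc23)c1` has not yet been measured. It carries methylsulfonyl in place of 2-cyanobenzyl on an amine nitrogen in a ring.

Among the measured compounds shown here, two measured steps bear on this change. Placing pyrrolidin-3-yl on the amide nitrogen gave a 2.9-fold higher number from compound 1 to compound 2 (0.46 log units; beyond the scatter). Adding 2-cyanobenzyl to the ring nitrogen then gave an at least 4.9-fold higher number from compound 2 to compound 3 (0.69 log units; beyond the scatter). Both are modest steps, but the second is the closer guide, since compound 4 loses the group added there. For the measured compounds named here, no measured step swaps one group on this nitrogen for another, so the expectation is loose. In this assay, a moderately lower number is expected, although another limit reading is possible. The expected change is an at least 1.8-fold lower number from compound 3 to compound 4 (0.26 log units; that floor lies within the scatter). The estimate for compound 4 is 100000 nM, with an expected range from 35000 nM to 200000 nM.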

Compound 4, half-maximal cytotoxic concentration: 24000 nM
For compound 4 the middle estimate is 4.2-fold (0.62 log units) above the measured one; the whole stated range lies above it.
By their numbers in this assay, from the lowest: compounds 1, 4 and 2 (each within the scatter of the next, the first and the last beyond it). At a limit, above all of these: compound 3.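

In this assay, the group on this ring nitrogen clearly matters, as swapping one group for another there gives a large drop (an at least 7.7-fold lower number from compound 3 to compound 4 (0.88 log units; beyond the scatter)). The high reading does not come with just any group on this nitrogen, since methylsulfonyl leaves compound 4 within the scatter of the compounds without it (a 1.6-fold lower number from compound 2 to compound 4 (0.19 log units; within the scatter); a 1.8-fold higher number from compound 1 to compound 4 (0.27 log units; within the scatter)). On these data alone, the true size of the drop stays unknown, as the reading for compound 3 is a limit and not a number: (the limit of >= 186000 nM in this assay, at which 1 of the 4 values shown sits).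

Which part of 2-cyanobenzyl goes with the high reading remains open, as a plain benzyl group would separate the aromatic ring from the nitrile. As far as these compounds go, it is also open where an acetyl group or a longer chain on this nitrogen would fall in this assay.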